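Piperidinyl substitution on the bare quinoline core of compound 1

The source may report more compounds than this note shows. Statements on the series, on what has been measured and on what is new or still open speak of the compounds shown alone.

Compound 1 `CC(CC(C)(C)C)Oc1cccc2cccnc12` is the unsubstituted member of this set: in an assay on cells with melanin-concentrating hormone receptor 1 (Homo sapiens) as the target, read by radioligand binding (a lower number here means a stronger inhibitor, a higher number a weaker inhibitor), compound 1 gives > 2000 nM, which is a limit of the assay and not a number (the limit of > 2000 nM in this assay, at which 1 of the 3 values shown sits). The two amino-bearing analogues set the scale of what the core can reach. Compound 2 `Nc1ccc2cccc(OCC3CCCC3)c2n1` gives 53 nM in this assay. Among the measured compounds shown here, compound 3 `COCC(C)Oc1cccc2ccc(N)nc12` gives 606 nM in this assay, and the step of an 11-fold higher number from compound 2 to compound 3 (1.06 log units; beyond the scatter) is the only measured step; it concerns the ether side chain and not the ring position that changes here.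

Compound 4 `CC(CC(C)(C)C)Oc1cccc2ccc(N3CCCCC3)nc12` keeps the ether side chain of compound 1 and differs from it by piperidin-1-yl in place of hydrogen on an aromatic carbon. For the measured compounds named here, no measured step bears on this change directly. The values of compound 2 and compound 3 show that analogues carrying a nitrogen substituent at this position fall well inside the measurable range, whereas compound 1 does not. A large step downward in this assay is therefore expected, an at least 10-fold lower number from compound 1 to compound 4 (1.00 log units; beyond the scatter), though a cyclic amine has not been measured on this core. Compound 4 is estimated at 200 nM, within 40 nM to 1500 nM.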

Compound 4, half-maximal inhibitory concentration: > 2000 nM
Compound 4 was reported as a limit; the forecaster's own chance of this, stated with the estimate: 15%; middle value at least 10-fold (1.00 log units) from the limit.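

In this assay, compound 1 and compound 4 both stand as limits and not as numbers, so no step between them can be read: the limit of > 2000 nM in this assay, at which 2 of the 4 values shown sit.

The compounds shown leave open whether piperidin-1-yl in place of hydrogen shifts the number at all, and whether it would give a readable value alongside the ether side chain of compound 2.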